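Phenylsulfonyl for benzyl on the shared core

The source may hold more compounds than are shown below. What is called first, only, known or untested is meant among the compounds shown, and "the series" means these compounds.

Measured compounds in a functional assay on Jurkat cells for inhibition of nuclear factor NF-kappa-B complex (Homo sapiens); on this read-out lower numbers stand for stronger inhibition and higher numbers for weaker inhibition:
compound 1 `CCOC(=O)c1cnc(SC)nc1NN1C(=O)C=C(C)C1=O`: 200 nM
compound 2 `CCOC(=O)c1cnc(CC2=CCCCC2)nc1NN1C(=O)C=C(C)C1=O`: 2000 nM
compound 3 `CCOC(=O)c1cnc(Cc2ccccc2)nc1NN1C(=O)C=C(C)C1=O`: 7000 nM

Compound 3 gives the highest number of the three in this assay. Compound 4 `CCOC(=O)c1cnc(S(=O)(=O)c2ccccc2)nc1NN1C(=O)C=C(C)C1=O` differs from it by phenylsulfonyl in place of benzyl on an aromatic carbon. Among the compounds with values here, no measured step changes the linking atom at this position; the steps that bear on it are a 35-fold higher number from compound 1 to compound 3 (1.54 log units; beyond the scatter), a 10-fold higher number from compound 1 to compound 2 (1.00 log units; beyond the scatter) and a 3.5-fold higher number from compound 2 to compound 3 (0.54 log units; beyond the scatter), which show this position to be sensitive, with the sulfur-linked compound 1 giving the lowest number. Within the data shown here, a sulfur-linked group may therefore bring the number back down, but the sulfonyl linkage has no precedent among the measured compounds, so only a moderate drop is expected, a 2.3-fold lower number from compound 3 to compound 4 (0.37 log units; beyond the scatter), with wide uncertainty. Compound 4 is estimated at 3000 nM, range 600 nM to 15000 nM.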

Compound 4, half-maximal inhibitory concentration: 10000 nM
Beside the measured number, compound 4's estimate is 3.3-fold (0.52 log units) below it; measured number inside the range.
By their numbers in this assay, from the lowest: compound 1; then compound 2; then compounds 3 and 4 (each within the scatter of the next).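

In this assay the step of a 1.4-fold higher number from compound 3 to compound 4 (0.15 log units; within the scatter) leaves compound 3 and compound 4 indistinguishable, so exchanging benzyl for phenylsulfonyl gives no resolvable change at this position. The steps of a 50-fold higher number from compound 1 to compound 4 (1.70 log units; beyond the scatter) and a 5.0-fold higher number from compound 2 to compound 4 (0.70 log units; beyond the scatter) show that a sulfur atom attached to the aromatic carbon does not by itself keep the number near that of compound 1. Nothing available explains this result.

Open, as far as these compounds go, is whether the sulfonyl or the phenyl separates compound 4 from compound 1. Methylsulfonyl and phenylsulfanyl at this position would divide those two changes, and a small amine would test a nitrogen link.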